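The source may hold more compounds than are shown below. What is called first, only, known or untested is meant among the compounds shown, and "the series" means these compounds.

Compound 2 `CC(Nc1ccc(C(=O)O)cc1)c1ccc(OCc2c(-c3c(Cl)cccc3Cl)noc2C2CC2)nc1C(F)(F)F` gives 101 nM in an assay on isolated protein for agonist activity at Bile acid receptor (Homo sapiens), read by FRET; a lower number here means that less compound is needed, a higher number that more compound is needed for the effect. Compound 1 `CC(C)c1onc(-c2c(Cl)cccc2Cl)c1COc1ccc(N(C)Cc2cccc(C(=O)NS(C)(=O)=O)c2)c(C(F)(F)F)n1` gives 48 nM in this assay, and compound 3 `CC(c1ccc(OCc2c(-c3c(Cl)cccc3Cl)noc2C2CC2)nc1C(F)(F)F)N(C)c1ccc(C(=O)O)cc1` gives 179 nM, so compound 2 stands second highest of the three numbers, close to compound 3 and furthest from compound 1. Compound 4 `O=C(O)c1ccc(OCc2ccc(OCc3c(-c4c(Cl)cccc4Cl)noc3C3CC3)nc2C(F)(F)F)cc1` differs from compound 2 by (4-carboxyphenoxy)methyl in place of 1-((4-carboxyphenyl)amino)ethyl on an aromatic carbon. Within the data shown here, the one measured step that bears on this change also took away the hydrogen on that nitrogen: a 1.8-fold higher number from compound 2 to compound 3 (0.25 log units; within the scatter). Compound 4 is therefore expected to show no step beyond the scatter, with a 1.5-fold higher number from compound 2 to compound 4 (0.17 log units; within the scatter), because a 1.8-fold higher number from compound 2 to compound 3 (0.25 log units; within the scatter) stayed within the scatter. The estimate for compound 4 is 150 nM, ranging from 50 nM to 450 nM.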

Compound 4, half-maximal effective concentration: 76 nM
The estimate for compound 4 lay 2.0-fold (0.30 log units) above the measured number; the measured number falls inside the stated range.
By their numbers in this assay, from the lowest: compounds 1, 4, 2 and 3 (each within the scatter of the next, the first and the last beyond it).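

Here the change gives a 1.3-fold lower number from compound 2 to compound 4 (0.12 log units; within the scatter) and removes the nitrogen altogether, whereas the earlier step only replaced its hydrogen with methyl. In this assay, then, this aromatic carbon carries (4-carboxyphenoxy)methyl as well as 1-((4-carboxyphenyl)amino)ethyl, and the nitrogen is not needed to keep the number within the scatter of compound 2. Nothing available explains this tolerance.

Still open, on these data alone, is whether a sulfur atom in place of the oxygen in (4-carboxyphenoxy)methyl would keep the number within the scatter. An amide in that chain poses the same question.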